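Hexyloxy for hexyl on the cyclohexyl core

The source may hold more compounds than are shown below. What is called first, only, known or untested is meant among the compounds shown, and "the series" means these compounds.

Measured so far in a functional assay on brain (Rattus norvegicus, strain Wistar) for inhibition; on this read-out higher numbers stand for weaker inhibition and lower numbers for stronger inhibition:
Compound 1, `CCCCCCc1ccc(-c2c(C)[nH]c(=O)n2C)cc1`, gives 9000 nM.
Compound 2, `CCCCCCOc1ccc(-c2c(C)[nH]c(=O)n2C)cc1`, gives 7300 nM.
Compound 3, `CCCCCCc1ccc(-c2c(C)[nH]c(=O)n2C2CCCCC2)cc1`, gives 13700 nM.

Compound 1 and compound 2 differ by hexyloxy in place of hexyl on an aromatic carbon, and the step is a 1.2-fold lower number from compound 1 to compound 2 (0.09 log units; within the scatter). The cores of compound 1 and compound 3 differ by cyclohexyl in place of methyl on an aromatic nitrogen, with a step of a 1.5-fold higher number from compound 1 to compound 3 (0.18 log units; within the scatter). Compound 4, `CCCCCCOc1ccc(-c2c(C)[nH]c(=O)n2C2CCCCC2)cc1`, is not yet measured and differs from compound 3 by hexyloxy in place of hexyl on an aromatic carbon. The place lines are not identical: in compound 1 the site is para to a group of 8 heavy atoms, in compound 3 para to a large group, so this is the same kind of change, not the same change. Because the earlier step was a 1.2-fold lower number from compound 1 to compound 2 (0.09 log units; within the scatter), compound 4 is expected to move from compound 3 by a 1.2-fold lower number from compound 3 to compound 4 (0.10 log units; within the scatter). Compound 4 is expected near 11000 nM, between 5000 nM and 25000 nM.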

Compound 4, half-maximal inhibitory concentration: 8500 nM
Compound 4: the middle estimate sits 1.3-fold (0.11 log units) above what was measured, within the range that was stated.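

In this assay, hexyloxy in place of hexyl on an aromatic carbon gives a 1.6-fold lower number from compound 3 to compound 4 (0.21 log units; within the scatter), and this step agrees with the earlier one: the same change on two cores in this assay, a 1.2-fold lower number (0.09 log units; within the scatter) from compound 1 to compound 2 and a 1.6-fold lower number (0.21 log units; within the scatter) from compound 3 to compound 4, 1.3-fold (0.12 log units) apart, within the scatter of two such steps. Cyclohexyl in place of methyl on an aromatic nitrogen gives a 1.2-fold higher number from compound 2 to compound 4 (0.07 log units; within the scatter), and it also agrees with its earlier counterpart: the same change on two cores in this assay, a 1.5-fold higher number (0.18 log units; within the scatter) from compound 1 to compound 3 and a 1.2-fold higher number (0.07 log units; within the scatter) from compound 2 to compound 4, 1.3-fold (0.12 log units) apart, within the scatter of two such steps. All these steps lie within the scatter, so the series shows that neither change produces a readable shift on either core, but it does not show that a real effect carries from one core to another.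

Still open, going by these compounds, is whether any group at these places moves the number beyond the scatter. A longer chain, an amine or a carboxylic acid in place of hexyloxy would test this.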